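Changing one aryl group in an antiproliferative series

The source may hold more compounds than are shown below. What is called first, only, known or untested is meant among the compounds shown, and "the series" means these compounds.

Compound 1 `O=C(COc1ccc(C(=O)/C=C/c2ccc(Cl)cc2Cl)cc1)N[C@H]1CCOC1=O`: 8040 nM
Compound 2 `O=C1OCC[C@@H]1NC(=S)SCCOc1cccc2ccccc12`: > 64000 nM

Of the compounds shown here, two have been tested in a functional assay on PC-3 cells (Homo sapiens) for antiproliferative activity, read by MTT assay, with a stated time of 72 h; on this read-out higher numbers stand for weaker inhibition and lower numbers for stronger inhibition. Among the measured compounds shown here, compound 1 gives 8040 nM and is the only compound here with a measured number rather than a limit. Compound 2 reaches only a limit of the assay, > 64000 nM, and this is the limit of > 64000 nM in this assay, at which 1 of the 2 values shown sits. For the measured compounds named here, no step between two measured compounds is available, so there is no measured change to lean on.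

Compound 3 `COc1ccccc1/C=C/C(=O)c1ccc(OCC(=O)N[C@H]2CCOC2=O)cc1` differs from compound 1 by 2-methoxyphenyl in place of 2,4-dichlorophenyl on a double-bonded chain carbon bound to a double-bonded chain carbon. Going by the values given here, with no measured step to set the size of such a change, the expected step is a 1.5-fold higher number from compound 1 to compound 3 (0.17 log units; within the scatter), which is meant as little beyond the scatter, leaning toward slightly weaker inhibition. Compound 3 is therefore expected to give about 12000 nM, with a likely range from 4000 nM to 40000 nM.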

Compound 3, half-maximal inhibitory concentration: 7240 nM
Estimate against measurement, compound 3: 1.7-fold (0.22 log units) above; the measured number falls inside the stated range.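

Among the compounds shown here, this is the first measured step, and it concerns the aryl group on a double-bonded chain carbon bound to a double-bonded chain carbon. In this assay, putting 2-methoxyphenyl in place of 2,4-dichlorophenyl gives a 1.1-fold lower number from compound 1 to compound 3 (0.05 log units; within the scatter). So at this place, the assay does not separate a ring carrying chlorine from one carrying a methoxy group, and chlorine is not needed to stay at this level of inhibition. Nothing measured here gives a reason for this result.

The swap removes the chlorines and adds the methoxy group in a single step, so the contribution of each one cannot be separated. Going by these compounds, how a phenyl ring bearing an amine or a carboxylic acid, or a saturated cyclohexyl group, would behave at this place remains open.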